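From furan-3-yl to thiophen-3-yl on a shared core

This account rests on a few compounds, and the source may have more. Where it says the series, first, only, none or still open, it means among the compounds named here.

In a functional assay on LN-229 cells (Homo sapiens) for antiproliferative activity, with a stated time of 72 h (on this read-out lower numbers stand for stronger inhibition and higher numbers for weaker inhibition), compound 1 (`Nc1ncnn2c([C@@H]3O[C@H](CO)[C@@H](O)[C@H]3O)cc(-c3ccc(F)cc3F)c12`) gives 43500 nM and compound 2 (`Nc1ncnn2c([C@@H]3O[C@H](CO)[C@@H](O)[C@H]3O)cc(-c3ccoc3)c12`) gives 1000 nM, the lower of the two numbers. Going by the values given here, the only measured step, a 44-fold lower number from compound 1 to compound 2 (1.64 log units; beyond the scatter), is a large one and comes with furan-3-yl in place of 2,4-difluorophenyl on an aromatic carbon. Compound 3 (`Nc1ncnn2c([C@@H]3O[C@H](CO)[C@@H](O)[C@H]3O)cc(-c3ccsc3)c12`) is changed at that same carbon, with thiophen-3-yl in place of furan-3-yl on an aromatic carbon. Among the compounds with values here, no measured step exchanges one five-membered aromatic ring for another, so the evidence is indirect. The step from compound 1 to compound 2, a 44-fold lower number from compound 1 to compound 2 (1.64 log units; beyond the scatter), shows that the number in this assay can move far with a change at this carbon, which argues for a wide range. With so close a swap, no step beyond the scatter is expected. The expected step is a 1.3-fold lower number from compound 2 to compound 3 (0.10 log units; within the scatter). For compound 3 the estimate is 800 nM, within a range of 200 nM to 3500 nM.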

Compound 3, half-maximal inhibitory concentration: 57700 nM
Estimate against measurement, compound 3: 72-fold (1.86 log units) below; the whole stated range lies below it.
By their numbers in this assay, from the lowest: compound 2; then compounds 1 and 3 (each within the scatter of the next).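

In this assay this aromatic carbon proves sensitive even to a swap between two five-membered aromatic rings with the same counts of heavy atoms, donors and acceptors: thiophen-3-yl in place of furan-3-yl gives a 58-fold higher number from compound 2 to compound 3 (1.76 log units; beyond the scatter). Thiophen-3-yl and 2,4-difluorophenyl, by contrast, cannot be told apart here, with a 1.3-fold higher number from compound 1 to compound 3 (0.12 log units; within the scatter), so furan-3-yl alone stands apart among the three groups, and ring size does not sort them, since the five-membered thiophen-3-yl falls with the six-membered 2,4-difluorophenyl. Nothing available accounts for the gap between furan-3-yl and thiophen-3-yl.

Whether the lower number is particular to furan-3-yl remains open, as the compounds shown do not tell how furan-2-yl or pyridin-3-yl would fare at this carbon. Nor do they show what an amine or a carboxylic acid on the furan ring would do.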